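The compounds below may be only part of what the source reports. "The series", "measured", "known", "first", "only" and "open" are said of these compounds alone.

Three compounds share a core in which a five-membered non-aromatic ring carrying two nitrogens bears a thiocarbonyl linked to an aniline, a 2,3-dihydro-1,4-benzodioxin-6-yl group, and an aromatic ring on the carbon with a double bond to nitrogen. Compound 1 `S=C(Nc1ccccc1)N1N=C(c2ccccc2)CC1c1ccc2c(c1)OCCO2` carries a plain phenyl there and, in a functional assay on WM 266-4 cells (Homo sapiens) for antiproliferative activity, read by MTT assay, with a stated time of 48 h (on this read-out lower numbers stand for stronger inhibition of growth and higher numbers for weaker inhibition of growth), compound 1 gives 3180 nM. Compound 2 `FC(F)(F)c1ccc(C2=NN(C(=S)Nc3ccccc3)C(c3ccc4c(c3)OCCO4)C2)cc1` carries a trifluoromethyl on that ring, and in this assay compound 2 gives 52400 nM, a change of a 16-fold higher number from compound 1 to compound 2 (1.22 log units; beyond the scatter). Compound 3 `CSc1ccc(C2=NN(C(=S)Nc3ccccc3)C(c3ccc4c(c3)OCCO4)C2)cc1` carries a methylsulfanyl instead, and in this assay compound 3 gives 197000 nM, the highest of the three numbers; the steps are a 62-fold higher number from compound 1 to compound 3 (1.79 log units; beyond the scatter) and a 3.8-fold higher number from compound 2 to compound 3 (0.58 log units; beyond the scatter).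

Compound 4 `S=C(Nc1ccccc1)N1N=C(c2ccc(Cl)c(Cl)c2)CC1c1ccc2c(c1)OCCO2` differs from compound 3 by 3,4-dichlorophenyl in place of 4-(methylsulfanyl)phenyl on a carbon with a double bond to nitrogen. Both earlier steps away from the plain phenyl raised the number by a large amount, while the exchange of one substituent for another was modest. A return toward the unsubstituted number is therefore plausible but uncertain. Compound 4 is expected to give about 30000 nM in this assay, within a range from 5000 nM to 150000 nM, which means an expected step of a 6.6-fold lower number from compound 3 to compound 4 (0.82 log units; beyond the scatter).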

Compound 4, concentration for 50% growth inhibition: 58700 nM
Compound 4: middle estimate off by 2.0-fold (0.29 log units), on the low side; the measured number falls inside the stated range.
By their numbers in this assay, from the lowest: compound 1; then compounds 2 and 4 (each within the scatter of the next); then compound 3.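

Moving from a single substituent to two chlorines on the aromatic ring does not bring the number back to that of the plain phenyl: in this assay there is an 18-fold higher number from compound 1 to compound 4 (1.27 log units; beyond the scatter), so all three substituted rings shown at this position, on a carbon with a double bond to nitrogen, sit well above compound 1. The substituted rings are not all alike, however: 3,4-dichlorophenyl gives a 3.4-fold lower number from compound 3 to compound 4 (0.53 log units; beyond the scatter), so the 4-(methylsulfanyl)phenyl ring remains the poorest of the four, while the comparison with 4-(trifluoromethyl)phenyl gives a 1.1-fold higher number from compound 2 to compound 4 (0.05 log units; within the scatter), so these two rings cannot be told apart in this assay. Nothing available here explains these differences.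

The compounds shown leave open whether any substituent on this ring can match or improve on the plain phenyl, for example a single fluorine, a methoxy, an amine or a carboxylic acid. They also leave open whether the same order of rings would hold if the aniline or the 2,3-dihydro-1,4-benzodioxin-6-yl group on the shared core were replaced.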